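Fluoro in Place of Hydrogen and Buffer Solubility

The source may report more compounds than this note shows. Statements on the series, on what has been measured and on what is new or still open speak of the compounds shown alone.

Compound 1 `CCOC(=O)c1ccc(Nc2ccnc(-c3cccnc3)n2)cc1` gives 61000 nM.
Compound 2 `CCOC(=O)c1ccc(Nc2ccnc(-c3cccnc3)n2)c(F)c1` gives 53000 nM.
Compound 3 `CC(=O)c1ccc(Nc2cc(C)nc(-c3cccnc3)n2)cc1` gives 94000 nM.

These three numbers come from a physicochemical assay for solubility, in phosphate buffer; a higher number here means a more soluble compound, a lower number a less soluble compound. Compound 2 differs from compound 1 by fluoro in place of hydrogen on an aromatic carbon, and the step was a 1.2-fold lower number from compound 1 to compound 2 (0.06 log units; within the scatter). How the core of compound 3 differs from the core of compound 1 is not broken down here; the values of compound 1 and compound 3 lie within the scatter of each other, as do those of compound 2 and compound 3.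

Compound 4 `CC(=O)c1ccc(Nc2cc(C)nc(-c3cccnc3)n2)cc1F` is the one not yet measured. It differs from compound 3 by fluoro in place of hydrogen on an aromatic carbon. This is the same kind of change as that from compound 1 to compound 2, though not the same: in compound 2 the fluoro sits ortho to a large group and meta to an ethoxycarbonyl group, whereas in compound 4 it sits ortho to an acetyl group and meta to a large group.

Within the data shown here, because the one measured instance of this change gave a 1.2-fold lower number from compound 1 to compound 2 (0.06 log units; within the scatter), the step from compound 3 to compound 4 in this assay is expected to be a 1.2-fold lower number from compound 3 to compound 4 (0.08 log units; within the scatter). Compound 4 is therefore estimated at 78000 nM, expected to fall between 40000 nM and 150000 nM.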

Compound 4, solubility: 32000 nM
Compound 4: the middle estimate sits 2.4-fold (0.39 log units) above what was measured, outside the stated range (below it).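

In this assay, fluoro in place of hydrogen on an aromatic carbon gave a 2.9-fold lower number from compound 3 to compound 4 (0.47 log units; beyond the scatter), whereas the same kind of change on the core of compound 1 gave a 1.2-fold lower number from compound 1 to compound 2 (0.06 log units; within the scatter), so the size of the step measured on one core did not carry over to the other in this series. Among these compounds, this does not show that the core alone sets the size of the step: there is only one pair on each core, and the two pairs differ in more than the core, since the fluoro of compound 4 sits ortho to an acetyl group, a place the fluoro of compound 2 does not share. No measurement offered here accounts for the difference between the two steps.

The compounds shown leave open whether the larger step belongs to the acetyl group, the core or the place of the fluoro. They also leave open how a chloro in that same place, or a carboxylic acid or an amine in place of the acetyl group, would read in this assay.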